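The compounds below may be only part of what the source reports. "The series", "measured", "known", "first", "only" and "open" are said of these compounds alone.

Three compounds have numbers in an assay on CHO cells for displacement of a labelled ligand from prostaglandin E2 receptor EP2 subtype (Mus musculus), read by scintillation counting, with a stated time of 60 min; a lower number here means a stronger inhibitor, a higher number a weaker inhibitor. Compound 1, `O=C(O)CCCSCCN1C(=O)CC[C@@H]1/C=C/[C@@H](O)Cc1cccc(-c2ccc3[nH]ccc3c2)c1`, gives 3500 nM in this assay. Compound 2, `O=C(O)CCCSCCN1C(=O)CC[C@@H]1/C=C/[C@@H](O)Cc1cccc(-c2cc3ccccc3o2)c1`, gives 2000 nM. The step of a 1.8-fold lower number from compound 1 to compound 2 (0.24 log units; within the scatter) shows that exchanging one bicyclic aromatic group for another on the shared core left the result within the scatter. Compound 3, `O=C(O)c1csc(SCCN2C(=O)CC[C@@H]2/C=C/[C@@H](O)Cc2cccc(-c3nc4ccccc4o3)c2)n1`, gives 28 nM and so stands lowest of the three, with a gap to compound 2 and to compound 1 that lies well beyond the scatter, which makes compound 3 the strongest inhibitor of the measured set.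

Compound 4, `Cc1cc(C)c2oc(-c3cccc(C[C@H](O)/C=C/[C@H]4CCC(=O)N4CCSc4nc(C(=O)O)cs4)c3)nc2c1`, is the same as compound 3 except for one change: 5,7-dimethyl-1,3-benzoxazol-2-yl in place of 1,3-benzoxazol-2-yl on an aromatic carbon. The group sits on an aromatic carbon of a six-membered aromatic ring of carbon only, meta to a large group. Going by the values given here, no measured step adds substituents to this bicyclic group; the only measured step, from compound 1 to compound 2, swapped the whole group and stayed within the scatter. With nothing pointing in either direction, the step of a 1.1-fold lower number from compound 3 to compound 4 (0.05 log units; within the scatter) is expected to stay within the scatter. Compound 4 is therefore estimated to give 25 nM in this assay, with a range from 8 nM to 80 nM.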

Compound 4, inhibition constant: 24 nM
Compound 4: middle estimate off by 1.0-fold (0.02 log units), on the high side; measured number inside the range.
By their numbers in this assay, from the lowest: compounds 4 and 3 (each within the scatter of the next); then compounds 2 and 1 (each within the scatter of the next).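

In this assay, replacing 1,3-benzoxazol-2-yl with 5,7-dimethyl-1,3-benzoxazol-2-yl gives a 1.2-fold lower number from compound 3 to compound 4 (0.07 log units; within the scatter), so adding two methyl groups to this bicyclic group leaves the result unchanged within the usual scatter. The earlier step between compound 1 and compound 2 exchanged one whole bicyclic group for another, whereas this step keeps the bicyclic group and adds to it, taking it from 9 to 11 heavy atoms on the same aromatic carbon, meta to a large group. Nothing here measures why the number holds, so the result gives no explanation for this tolerance.

Going by these compounds alone, with only this one substituted pair, it remains unknown whether the tolerance belongs to methyl groups alone or extends to other substituents on the bicyclic group, such as a chlorine atom, a methoxy group, an amine or a carboxylic acid. It is also unknown what a single methyl group or a longer chain such as propyl would do, and whether either would keep the number within the scatter of compound 3.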